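Thiazolyl for chlorophenyl at the carbinol carbon: cytotoxicity outlook

The source may report more compounds than this note shows. Statements on the series, on what has been measured and on what is new or still open speak of the compounds shown alone.

Compound 1 `OC(c1ccc(Cl)cc1)(c1cccnc1)c1ccccc1Cl` gives 61300 nM in an ADME assay on L6 cells (Rattus norvegicus) for cytotoxicity, read by resazurin assay, with a stated time of 72 h (a lower number here means a stronger inhibitor, a higher number a weaker inhibitor), the lowest of the two numbers in hand. Compound 3 `Clc1ccc(C(c2cccnc2)c2ccccc2Cl)cc1` gives 62300 nM in this assay, and the step of a 1.0-fold higher number from compound 1 to compound 3 (0.01 log units; within the scatter) stays within the scatter. Compound 2 `OC(c1ccc(Cl)cc1)(c1ncccn1)c1ccccc1Cl` reaches only a limit in this assay, > 100000 nM, which is the limit of > 100000 nM in this assay, at which 1 of the 3 values shown sits. The step of an at least 1.6-fold higher number from compound 1 to compound 2 (0.21 log units; that floor lies within the scatter) is therefore known only as a floor.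

Compound 4 `OC(c1ccc(Cl)cc1)(c1cccnc1)c1cncs1` differs from compound 1 by 1,3-thiazol-5-yl in place of 2-chlorophenyl on a saturated chain carbon bound to two aromatic carbons and an oxygen on a saturated carbon. For the measured compounds named here, the only measured step at this carbon is the floor from compound 1 to compound 2, and no measured step swaps an aromatic ring for a five-membered one. No step beyond the scatter is expected, with a slight lean toward a higher number. Compound 4 is expected at 85000 nM, between 40000 nM and 180000 nM. The expected step is a 1.4-fold higher number from compound 1 to compound 4 (0.14 log units; within the scatter).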

Compound 4, half-maximal inhibitory concentration: > 100000 nM
Compound 4 was reported as a limit; the forecaster's own chance of this, stated with the estimate: 35%; middle value at least 1.1-fold (0.07 log units) from the limit.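

Putting 1,3-thiazol-5-yl in place of 2-chlorophenyl gives an at least 1.6-fold higher number from compound 1 to compound 4 (0.21 log units; that floor lies within the scatter) in this assay. Compound 4 is reported only as a limit, a second such result in the series: the limit of > 100000 nM in this assay, at which 2 of the 4 values shown sit. Exchange of the 2-chlorophenyl ring, and not only of pyridin-3-yl, therefore also ends at a limit, but the floor does not establish a change beyond the scatter.

As far as these compounds go, the true size of this step remains open. Also open, from the compounds shown here alone, is whether an amine or a carboxylic acid in place of 2-chlorophenyl at this carbon would give a measurable number.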